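Benzylation of an Anilino Nitrogen on Two Fused Cores

A few compounds are considered here, and "the series" means these few. Any claim that something is new, unique, unknown or untested is made for them only; others in the source may bear on it.

Compound 1, `COc1cc(OC)n2cc(-c3ccc(NCc4ccccc4)cc3)nc2n1`: > 100000 nM
Compound 2, `COc1cc(OC)n2cc(-c3ccc(N(Cc4ccccc4)Cc4ccccc4)cc3)nc2n1`: > 100000 nM
Compound 3, `Cc1ccn2cc(-c3ccc(NCc4ccccc4)cc3)nc2c1`: "not determined" (no result reported)

In a functional assay on HepG2 cells (Homo sapiens) for antiproliferative activity, read by MTT assay, with a stated time of 72 h (on this read-out higher numbers stand for weaker inhibition of growth and lower numbers for stronger inhibition of growth), compound 1 gives > 100000 nM, which is a limit of the assay and not a number. In this assay compound 2 likewise gives > 100000 nM, again a limit. The change between them is benzyl in place of hydrogen on a nitrogen on an aromatic ring, and the step that the two limits leave unreadable from compound 1 to compound 2 cannot be read because of the limit of > 100000 nM in this assay, at which 2 of the 3 values shown sit. Compound 3, `Cc1ccn2cc(-c3ccc(NCc4ccccc4)cc3)nc2c1`, carries a different core; the difference between the two cores is not broken down here, and compound 3 has no reported result in this assay. Compound 4, `Cc1ccn2cc(-c3ccc(N(Cc4ccccc4)Cc4ccccc4)cc3)nc2c1`, is the unmeasured partner of compound 3, and the change benzyl in place of hydrogen on a nitrogen on an aromatic ring is the same change as that from compound 1 to compound 2, made at the same place. Within the data shown here, with compound 3 undetermined, no size of step can be estimated for this pair beyond what compound 1 and compound 2 show, which is two limits. Compound 4 is therefore expected to sit at 100000 nM, with a wide range from 20000 nM to 300000 nM, and most likely to be reported only as a limit.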

Compound 4, concentration for 50% growth inhibition: 18400 nM
The estimate for compound 4 lay 5.4-fold (0.74 log units) above the measured number; measured number below the stated range.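

In this assay compound 3 stands as "not determined" (no result reported), while compound 4 gives 18400 nM, so no new step can be read from this pair. The compounds shown leave open what benzyl in place of hydrogen on a nitrogen on an aromatic ring does to growth inhibition on the core of compound 3.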